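The source may hold more compounds than are shown below. What is called first, only, known or untested is meant among the compounds shown, and "the series" means these compounds.

Compound 2 `CCC(CC)O[C@@H]1C=C(C(=O)O)C[C@H](NCc2ccc(OC)cc2)[C@H]1NC(C)=O` is the starting point in an ADME assay on cells (Fibroblast, Gallus gallus) for cytotoxicity, read by CCK-8 assay, with a stated time of 48 h; a lower number here means that less compound is tolerated, a higher number that more compound is tolerated. In this assay compound 2 gives > 200000 nM, which is a limit of the assay rather than a number. Compound 1 `CCC(CC)O[C@@H]1C=C(C(=O)O)C[C@H](NCc2ccc(C(C)(C)C)cc2)[C@H]1NC(C)=O` gives > 200000 nM in this assay, again a limit. Compound 3 `CCC(CC)O[C@@H]1C=C(C(=O)O)C[C@H](NCc2ccc(Oc3ccccc3)cc2)[C@H]1NC(C)=O` gives > 200000 nM in this assay, also a limit. All three sit at the limit of > 200000 nM in this assay, at which 3 of the 3 values shown sit, so the steps a step that the two limits leave unreadable from compound 1 to compound 2, a step that the two limits leave unreadable from compound 1 to compound 3 and a step that the two limits leave unreadable from compound 2 to compound 3 cannot be read in size. Compound 4 `CCC(CC)O[C@@H]1C=C(C(=O)O)C[C@H](NCc2ccc(-c3cc4ccccc4s3)cc2)[C@H]1NC(C)=O` is not yet measured; it differs from compound 2 by 1-benzothiophen-2-yl in place of methoxy on an aromatic carbon. Every measured change at this position left the value at the limit of > 200000 nM in this assay, at which 3 of the 3 values shown sit. A step beyond the scatter is therefore not expected, and the step that the limit leaves unreadable from compound 2 to compound 4 is expected to be small. Compound 4 is estimated to give 250000 nM in this assay, within 60000 nM to 1000000 nM.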

Compound 4, half-maximal cytotoxic concentration: > 200000 nM
Compound 4 ended at the assay's limit; the forecaster's own chance of this, stated with the estimate: 75%; the middle value is on the limit's open side.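

In this assay compound 4 gives > 200000 nM, which is a limit of the assay. Its steps from compound 1, compound 2 and compound 3 therefore cannot be read in size. The compounds shown leave open at what concentration any of them harms these cells, and whether the groups compared differ at all.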